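The source may report more compounds than this note shows. Statements on the series, on what has been measured and on what is new or still open speak of the compounds shown alone.

Three compounds share a core carrying an aromatic amine with a basic side chain and an ether on the ring. Compound 2 `CCOc1ccc2c(NCCN(C)C)ccnc2c1` gives 5680 nM in a functional assay on HepG2 cells (Homo sapiens) for cytotoxicity, read by MTT assay, with a stated time of 48 h; on this read-out lower numbers stand for stronger inhibition and higher numbers for weaker inhibition. Compound 1 `C=CCOc1ccc2c(NCCN(C)C)ccnc2c1` gives 1660 nM in this assay; the difference between the two is vinyl in place of methyl on a saturated chain carbon bound to an oxygen on an aromatic ring, and it made a 3.4-fold lower number from compound 2 to compound 1 (0.53 log units; beyond the scatter). Compound 3 `CCOc1ccc2c(NCCCN(C)C)ccnc2c1` gives 5860 nM in this assay; it differs from compound 2 by (dimethylamino)methyl in place of dimethylamino on a saturated chain carbon, two bonds along the chain from a nitrogen on an aromatic ring, a change that made a 1.0-fold higher number from compound 2 to compound 3 (0.01 log units; within the scatter), so the two numbers cannot be told apart.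

Compound 4 `C=CCOc1ccc2c(NCCCN(C)C)ccnc2c1` has not been measured. It differs from compound 3 by vinyl in place of methyl on a saturated chain carbon bound to an oxygen on an aromatic ring, the same change as from compound 2 to compound 1, in the same place. Among the compounds shown this change occurs twice, and the one measured instance is the only guide. Since the longer side chain of compound 3 made no difference beside compound 2, the step from compound 3 to compound 4 is expected to resemble the earlier one; the estimate is a 3.3-fold lower number from compound 3 to compound 4 (0.52 log units; beyond the scatter). Compound 4 is therefore expected to give about 1750 nM, likely between 850 nM and 3600 nM.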

Compound 4, half-maximal inhibitory concentration: 3990 nM
Beside the measured number, compound 4's estimate is 2.3-fold (0.36 log units) below it; the whole stated range lies below it.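

In this assay, changing ethoxy to allyloxy on the core of compound 3 gave a 1.5-fold lower number from compound 3 to compound 4 (0.17 log units; within the scatter), and this step cannot be distinguished from its earlier counterpart: the same change on two cores in this assay, a 3.4-fold lower number (0.53 log units; beyond the scatter) from compound 2 to compound 1 and a 1.5-fold lower number (0.17 log units; within the scatter) from compound 3 to compound 4, 2.3-fold (0.37 log units) apart, within the scatter of two such steps

The change from dimethylamino to (dimethylamino)methyl on the allyloxy core gave a 2.4-fold higher number from compound 1 to compound 4 (0.38 log units; beyond the scatter), and it likewise cannot be distinguished from its earlier counterpart: the same change on two cores in this assay, a 1.0-fold higher number (0.01 log units; within the scatter) from compound 2 to compound 3 and a 2.4-fold higher number (0.38 log units; beyond the scatter) from compound 1 to compound 4, 2.3-fold (0.37 log units) apart, within the scatter of two such steps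

Both changes are therefore consistent with carrying over from one core to the other, but this does not prove that they carry over unchanged, since each has only two instances and in each pair one step lies within the scatter and the other beyond it.

The compounds shown leave open whether any effect of allyloxy depends on its double bond or only on the extra carbon, a question that a propoxy group could help answer. They also leave open how a longer chain, or a piperidine in place of dimethylamino, would behave.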